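Phenoxy for phenyl at the distal ring of compound 1

The source may hold more compounds than are shown below. What is called first, only, known or untested is meant among the compounds shown, and "the series" means these compounds.

Measured compounds:
Compound 1, `COC(=O)c1ccc(-c2cnc(C(=O)CCc3ccc(-c4ccccc4)cc3)o2)nc1`, gives 2.2 nM.
Compound 2, `CN(C)C(=O)c1cnc(C(=O)CCc2ccc(-c3ccccc3)cc2)o1`, gives 3 nM.
Compound 3, `NC(=O)c1ccc(-c2cnc(C(=O)CCc3ccc(-c4ccccc4)cc3)o2)nc1`, gives 1.3 nM.

These three values come from an assay for inhibition of Fatty-acid amide hydrolase 1 (Rattus norvegicus); on this read-out lower numbers stand for stronger inhibition and higher numbers for weaker inhibition. Compound 1 stands second highest of the three numbers: its nearest neighbour is compound 2, reached by a 1.4-fold higher number from compound 1 to compound 2 (0.13 log units; within the scatter), and its furthest is compound 3, reached by a 1.7-fold lower number from compound 1 to compound 3 (0.23 log units; within the scatter). Between the other two the gap is a 2.3-fold lower number from compound 2 to compound 3 (0.36 log units; beyond the scatter).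

Compound 4, `COC(=O)c1ccc(-c2cnc(C(=O)CCc3ccc(Oc4ccccc4)cc3)o2)nc1`, has not yet been measured in this assay. It differs from compound 1 in one place: phenoxy in place of phenyl on an aromatic carbon. All three measured steps concern the other end of the shared core, the group on the aromatic carbon of the oxazole and the carbonyl substituent, and none of them touches the distal ring where the change in compound 4 occurs. Among the measured compounds shown here, no measured step therefore bears on it, and the expectation rests only on the narrow spread of the three values, all close to compound 1.

In this assay compound 4 is estimated at 3 nM, with a range from 0.8 nM to 12 nM. The step this estimate means, a 1.4-fold higher number from compound 1 to compound 4 (0.13 log units; within the scatter), is expected to lie within the scatter, with no direction foreseen beyond it.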

Compound 4, inhibition constant: 54 nM
Compound 4: the middle estimate sits 18-fold (1.26 log units) below what was measured, and the stated range ends below it.
By their numbers in this assay, from the lowest: compounds 3, 1 and 2 (each within the scatter of the next, the first and the last beyond it); then compound 4.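

Moving from phenyl to phenoxy on an aromatic carbon para to a large group shows that the distal end of the shared core is not a free position in this assay: one added oxygen, with the distal ring otherwise unchanged, gives a large loss (a 25-fold higher number from compound 1 to compound 4 (1.39 log units; beyond the scatter)). The other end of the core had shown much smaller changes among the earlier compounds, where even the one step beyond the scatter was modest (a 2.3-fold lower number from compound 2 to compound 3 (0.36 log units; beyond the scatter)). Nothing available explains why this single replacement costs so much, so the added oxygen and its hydrogen-bond acceptor can be counted but not held responsible.

As far as these compounds go, what remains open is whether the loss belongs to the oxygen itself or to any linking atom at this carbon, a question that a benzyl or an anilino group in place of phenoxy would address. Also open, from the compounds shown here alone, is whether the same replacement would cost as much on the primary carboxamide of compound 3, and whether a smaller group on this carbon, such as methoxy or fluorine, would fare any better.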